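Replacing a Thiophene Amide with a Trifluoromethylphenyl Amide

This account rests on a few compounds, and the source may have more. Where it says the series, first, only, none or still open, it means among the compounds named here.

Of the compounds shown here, three built on one shared core have been measured in a physicochemical assay for solubility, at pH 7; on this read-out higher numbers stand for higher solubility and lower numbers for lower solubility. Compound 1, `CN1CCC(C(=O)N2Cc3c(NC(=O)c4ccsc4)n[nH]c3C2(C)C)CC1`, gives > 225000 nM, which is a limit of the assay and not a number. Compound 2, `CCCNC(=O)Nc1n[nH]c2c1CN(C(=O)C1CCN(C)CC1)C2(C)C`, gives > 225000 nM, again a limit. Going by the values given here, compound 3, `CN1CCC(C(=O)N2Cc3c(NC(=O)c4cccs4)n[nH]c3C2(C)C)CC1`, is the only one with a true number: in this assay compound 3 gives 155000 nM. Compound 3 therefore stands as the single measured point, while the other two values sit at the limit of > 225000 nM in this assay, at which 2 of the 3 values shown sit.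

Compound 4, `CN1CCC(C(=O)N2Cc3c(NC(=O)c4ccc(C(F)(F)F)cc4)n[nH]c3C2(C)C)CC1`, is not yet measured. It differs from compound 3 in one place: 4-(trifluoromethyl)phenyl in place of thiophen-2-yl on a carbonyl carbon. The measured steps on this carbonyl carbon were an at least 1.4-fold lower number from compound 1 to compound 3 (0.16 log units; that floor lies within the scatter) and an at least 1.4-fold lower number from compound 2 to compound 3 (0.16 log units; that floor lies within the scatter); neither involves a 4-(trifluoromethyl)phenyl group, so they do not tell how the number will move. With no direct guide, compound 4 is estimated at 40000 nM, within a range from 8000 nM to 150000 nM. That estimate corresponds to an expected step of a 3.9-fold lower number from compound 3 to compound 4 (0.59 log units; beyond the scatter), in the direction of a lower number.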

Compound 4, solubility: 191000 nM
For compound 4 the middle estimate is 4.8-fold (0.68 log units) below the measured one; measured number above the stated range.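

In this assay the exchange of thiophen-2-yl, with 5 heavy atoms, for 4-(trifluoromethyl)phenyl, with 10 heavy atoms, gives a 1.2-fold higher number from compound 3 to compound 4 (0.09 log units; within the scatter), so on this carbonyl carbon a larger six-membered aromatic ring of carbon only leaves the read-out within the usual scatter of a five-membered aromatic ring. The comparisons with the other two compounds give only floors, an at least 1.1-fold lower number from compound 2 to compound 4 (0.07 log units; that floor lies within the scatter) and an at least 1.1-fold lower number from compound 1 to compound 4 (0.07 log units; that floor lies within the scatter), and both of these also lie within the scatter. Those floors say little, because compound 1 and compound 2 each stand at a limit of the assay and not at a number: the limit of > 225000 nM in this assay, at which 2 of the 4 values shown sit.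

As far as these compounds go, it remains open whether a plain phenyl ring would read like the 4-(trifluoromethyl)phenyl group. From the compounds shown here alone, it is also open whether a ring carrying an amine or a carboxylic acid at this carbonyl carbon would move the number beyond the scatter.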